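Swapping Methoxy for Chloro on the Core of Compound 1

The source may hold more compounds than are shown below. What is called first, only, known or untested is meant among the compounds shown, and "the series" means these compounds.

Compound 1 `COc1ccc(-c2nc3ccccn3c2C(=O)/C=C\Nc2cc(OC)cc(OC)c2)cc1` was tested in a functional assay on HeLa cells (Homo sapiens) for cytotoxicity, read by MTT assay, with a stated time of 48 h (a lower number here means a stronger inhibitor, a higher number a weaker inhibitor), where compound 1 gives 4570 nM, the lowest of the three numbers recorded so far. Compound 2 `COc1ccc(-c2nc3ccccn3c2C(=O)/C=C\Nc2ccc3[nH]ccc3c2)cc1` gives 13600 nM in this assay, and compound 3 `COc1ccc(-c2nc3ccccn3c2C(=O)/C=C\Nc2ccc3cc[nH]c3c2)cc1` gives 15300 nM. Both steps away from compound 1 run in the same direction: a 3.0-fold higher number from compound 1 to compound 2 (0.47 log units; beyond the scatter), and a 3.3-fold higher number from compound 1 to compound 3 (0.52 log units; beyond the scatter); between the other two, a 1.1-fold higher number from compound 2 to compound 3 (0.05 log units; within the scatter). All three measured steps, however, change only the aryl group on the amine nitrogen.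

Compound 4 `COc1cc(N/C=C\C(=O)c2c(-c3ccc(Cl)cc3)nc3ccccn23)cc(OC)c1` has not yet been measured. It differs from compound 1 in one place: chloro in place of methoxy on an aromatic carbon. Within the data shown here, none of the measured steps touches this position, so they give no direct guidance on the size or direction of the change. The variation seen on the other side of the shared core has been modest, and the chemist assumes the same here. He expects compound 4 to stay close to compound 1, with an estimated step of a 1.1-fold higher number from compound 1 to compound 4 (0.04 log units; within the scatter) in this assay, most likely within the scatter. Compound 4 is therefore estimated at 5000 nM, in the range from 1500 nM to 16000 nM.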

Compound 4, half-maximal inhibitory concentration: 14600 nM
Compound 4: middle estimate off by 2.9-fold (0.47 log units), on the low side; the measured number falls inside the stated range.
By their numbers in this assay, from the lowest: compound 1; then compounds 2, 4 and 3 (each within the scatter of the next).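

In this assay, chloro in place of methoxy gives a 3.2-fold higher number from compound 1 to compound 4 (0.50 log units; beyond the scatter), so this place on the core, para to a large group, does respond to a single change. The earlier compounds shown here could not show this, as they varied only the aryl group on the amine nitrogen, and the change from 4-methoxyphenyl to 4-chlorophenyl now shows that the number also moves with a change at a second site, in the same direction as a 3.0-fold higher number from compound 1 to compound 2 (0.47 log units; beyond the scatter) and a 3.3-fold higher number from compound 1 to compound 3 (0.52 log units; beyond the scatter), with compound 1 still giving the lowest number of the four. Nothing shown here explains why this swap raises the number.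

With only methoxy and chloro shown at this place, it remains open whether the step reflects the loss of methoxy or the arrival of chloro, and how an amine, a hydroxyl or a longer chain such as ethoxy would read on the same carbon. Also open, on these data alone, is whether the same swap gives a step of this size with 1H-indol-5-yl or 1H-indol-6-yl on the amine nitrogen.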